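This account rests on a few compounds, and the source may have more. Where it says the series, first, only, none or still open, it means among the compounds named here.

Series notes. Compound 1 `COc1ccc(/C=C/C(=O)c2ccc(OC)c(N)c2)cc1` and compound 3 `COc1ccc(C(=O)/C=C/c2ccc(OC)c(OC)c2)cc1N` share a core and differ in one place, (methoxy in place of hydrogen on an aromatic carbon), which gives a 2.4-fold lower number from compound 1 to compound 3 (0.38 log units; beyond the scatter) in a functional assay on B16 cells (Mus musculus) for cytotoxicity, read by MTT assay, with a stated time of 3 days; on this read-out lower numbers stand for stronger inhibition and higher numbers for weaker inhibition: compound 1 gives 43000 nM and compound 3 gives 18000 nM. Compound 2 `COc1cccc(/C=C/C(=O)c2ccc(OC)c([N+](=O)[O-])c2)c1` differs from compound 1 in more than one place, and the difference between the two cores is not broken down here. In this assay compound 2 gives only a limit, > 100000 nM, which is the limit of > 100000 nM in this assay, at which 1 of the 3 values shown sits. Compound 4 `COc1ccc(OC)c(/C=C/C(=O)c2ccc(OC)c([N+](=O)[O-])c2)c1`, not yet measured, follows from compound 2 by methoxy in place of hydrogen on an aromatic carbon. For the measured compounds named here, this is the same kind of change as the one from compound 1 to compound 3, not the same: there the entering methoxy is ortho to a methoxy group and meta to a large group, here it is ortho to a large group and para to a methoxy group. Resting on the modest 2.4-fold lower number from compound 1 to compound 3 (0.38 log units; beyond the scatter) and on compound 2 standing at the limit of > 100000 nM in this assay, at which 1 of the 3 values shown sits, the expected step is an at least 1.2-fold lower number from compound 2 to compound 4 (0.09 log units; that floor lies within the scatter), with a fair chance that again only a limit is returned. Compound 4 is therefore estimated at 80000 nM, between 30000 nM and 200000 nM.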

Compound 4, half-maximal inhibitory concentration: 13000 nM
Compound 4: middle estimate off by 6.2-fold (0.79 log units), on the high side; the measured number lies below the stated range.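

In this assay, methoxy in place of hydrogen on an aromatic carbon gives an at least 7.6-fold lower number from compound 2 to compound 4 (0.88 log units; beyond the scatter), and the size of this change does not carry over intact from the earlier core: the same change on two cores in this assay, a 2.4-fold lower number (0.38 log units; beyond the scatter) from compound 1 to compound 3 and an at least 7.6-fold lower number (0.88 log units; beyond the scatter) from compound 2 to compound 4, at least 3.2-fold (0.50 log units) apart, beyond the scatter of two such steps. From the compounds shown here alone, compound 2 stands at > 100000 nM, a limit of the assay and not a number, so the new step gives only a floor and its true size stays unknown: the limit of > 100000 nM in this assay, at which 1 of the 4 values shown sits. Both steps point the same way, but the entering methoxy is ortho to a large group and para to a methoxy group on the way to compound 4 and ortho to a methoxy group and meta to a large group on the way to compound 3, so these two pairs cannot separate the effect of place from that of the core.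

Going by these compounds, it remains open whether methoxy at each of these two places gives a similar step on the other core. Also open, on these data alone, is how an ethoxy group or a hydroxyl group on the same aromatic carbon would compare with methoxy.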